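The source may hold more compounds than are shown below. What is called first, only, known or untested is meant among the compounds shown, and "the series" means these compounds.

Measured compounds:
- compound 1 `Cc1ccc(NC(=O)C2CCN(C/C=C/c3ccccc3)CC2)cc1`: 30000 nM
- compound 2 `CCCc1ccc(NC(=O)C2CCN(C/C=C/c3ccccc3)CC2)cc1`: 9030 nM
- compound 3 `COc1ccc(NC(=O)C2CCN(C/C=C/c3ccccc3)CC2)cc1`: > 100000 nM

In a functional assay on MCF7 cells (Homo sapiens) for inhibition, read by MTT assay, with a stated time of 72 h (a higher number here means a weaker inhibitor, a lower number a stronger inhibitor), compound 1 gives 30000 nM, the higher of the two numbers in hand; compound 2 sits nearest, and the step of a 3.3-fold lower number from compound 1 to compound 2 (0.52 log units; beyond the scatter) carries ethyl in place of hydrogen on a saturated chain carbon bound to an aromatic carbon. Compound 3 reports only a limit in this assay, > 100000 nM; that limit is the limit of > 100000 nM in this assay, at which 1 of the 3 values shown sits. The step of an at least 3.3-fold higher number from compound 1 to compound 3 (0.52 log units; beyond the scatter) covers methoxy in place of methyl on an aromatic carbon, and an at least 11-fold higher number from compound 2 to compound 3 (1.04 log units; beyond the scatter) covers methoxy in place of propyl.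

Compound 4 `O=C(Nc1ccccn1)C1CCN(C/C=C/c2ccccc2)CC1` is the unmeasured member. Its change from compound 1 is pyridin-2-yl in place of 4-methylphenyl on an amide-type nitrogen. Among the measured compounds shown here, no measured step exchanges the ring itself, so the bearing is indirect: within the series a longer chain lowered the number (a 3.3-fold lower number from compound 1 to compound 2 (0.52 log units; beyond the scatter)) while methoxy raised it beyond the limit (an at least 3.3-fold higher number from compound 1 to compound 3 (0.52 log units; beyond the scatter)). Losing the 4-methylphenyl for pyridin-2-yl is therefore expected to move the number upward, roughly a 2.0-fold higher number from compound 1 to compound 4 (0.30 log units; within the scatter). The expected value for compound 4 in this assay is 60000 nM, with a range from 20000 nM to 200000 nM; a limit-only result is a real possibility.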

Compound 4, half-maximal inhibitory concentration: 67200 nM
Beside the measured number, compound 4's estimate is 1.1-fold (0.05 log units) below it; measured number inside the range.
By their numbers in this assay, from the lowest: compound 2; then compound 1; then compound 4. At a limit, above all of these: compound 3.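

In this assay, the ring on the amide-type nitrogen can be exchanged with the result still a number rather than a limit, though pyridin-2-yl in place of 4-methylphenyl gives a weaker inhibitor: a 2.2-fold higher number from compound 1 to compound 4 (0.35 log units; beyond the scatter). Against the propyl member the gap is wider, a 7.4-fold higher number from compound 2 to compound 4 (0.87 log units; beyond the scatter), and compound 2 keeps the lowest number of the series. The reading an at least 1.4-fold lower number from compound 3 to compound 4 (0.17 log units; that floor lies within the scatter) starts from a limit, and its floor settles no order between those two: the limit of > 100000 nM in this assay, at which 1 of the 4 values shown sits.

The compounds shown leave open how much of the step belongs to the ring nitrogen and how much to the lost methyl, a split that an unsubstituted phenyl would address. Also open, on these data alone, is whether a propyl group, an amine or a carboxylic acid on the pyridin-2-yl ring would recover the lost ground.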